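The source may report more compounds than this note shows. Statements on the series, on what has been measured and on what is new or still open speak of the compounds shown alone.

Measured so far in a functional assay on HepG2 cells (Homo sapiens) for cytotoxicity, read by MTT assay, with a stated time of 72 h; on this read-out lower numbers stand for stronger inhibition and higher numbers for weaker inhibition:
- compound 1 `CNC(=O)c1cc(Oc2ccc(C(=O)/C=C/c3ccco3)cc2)ccn1` gives "not determined" (no result reported)
- compound 2 `CNC(=O)c1cc(Oc2ccc(C(=O)/C=C/c3ccc(OC)c(OC)c3OC)cc2)ccn1` gives 9810 nM
- compound 3 `CNC(=O)c1cc(Oc2ccc(C(=O)/C=C/c3ccc(F)cc3Cl)cc2)ccn1` gives 7320 nM

Among the measured compounds shown here, only two numbers are available for comparison, because compound 1 has no reported result. For the measured compounds named here, compound 3 at 7320 nM and compound 2 at 9810 nM lie within the scatter of each other, so compound 3 stands level with the only other number.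

Still to be measured is compound 4 `CNC(=O)c1cc(Oc2ccc(C(=O)/C=C/c3cccc(Cl)c3Cl)cc2)ccn1`, which carries 2,3-dichlorophenyl in place of 2-chloro-4-fluorophenyl on a double-bonded chain carbon bound to a double-bonded chain carbon. Going by the values given here, no measured pair differs in one place only, so the series offers no direct step size for this change. Among the compounds with values here, the sole guide is that compound 2 at 9810 nM and compound 3 at 7320 nM carry different groups at this place and show no gap beyond the scatter, which is thin evidence from two numbers.

In this assay no step beyond the scatter is expected in either direction, and the estimated step is a 1.1-fold lower number from compound 3 to compound 4 (0.05 log units; within the scatter) in that light. For compound 4 the expected value is 6500 nM, with an estimated range from 2500 nM to 15000 nM.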

Compound 4, half-maximal inhibitory concentration: > 50000 nM
Compound 4 ended at the assay's limit; the forecaster's own chance of this, stated with the estimate: 8%; at least 7.6-fold (0.88 log units) between middle value and limit.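

In this assay compound 4 gives > 50000 nM, a limit of the assay and not a number. With 2,3-dichlorophenyl in place of 2-chloro-4-fluorophenyl on a double-bonded chain carbon bound to a double-bonded chain carbon, the series gives its first one-place comparison, an at least 6.8-fold higher number from compound 3 to compound 4 (0.83 log units; beyond the scatter), so a change at this place can move the read-out beyond the scatter even though the two groups match in heavy-atom count, in their single six-membered aromatic ring of carbon only and in their counts of hydrogen-bond donors and acceptors. The true size of this step stays unknown and may be larger than printed, and the limit is reached by one compound only: the limit of > 50000 nM in this assay, at which 1 of the 4 values shown sits.

A 2,4-dichlorophenyl group at this place would help separate the exchange of fluorine for chlorine from the change in where the halogens sit, and the two compounds compared here cannot tell these two apart. Why the swap has this effect also stays open, and so does the standing of the furan-bearing compound 1, which gives "not determined" (no result reported).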